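Aryl variation on a pyrazolopyrimidine sigma-1 series

This account rests on a few compounds, and the source may have more. Where it says the series, first, only, none or still open, it means among the compounds named here.

Measured so far:
compound 1 `Clc1ccc(-c2ncnc3c2cnn3CCN2CCCCC2)cc1`: 43 nM
compound 2 `Cc1cc(F)ccc1-c1ncnc2c1cnn2CCN1CCCCC1`: 48 nM

In an assay on HEK293 cells for displacement of a labelled ligand from Sigma non-opioid intracellular receptor 1 (Homo sapiens), read by scintillation counting, with a stated time of 120 min (a higher number here means a weaker inhibitor, a lower number a stronger inhibitor), compound 1 gives 43 nM and compound 2 gives 48 nM. Among the compounds with values here, compound 2 holds the highest of the two numbers, but its only neighbour is compound 1, and the step of a 1.1-fold higher number from compound 1 to compound 2 (0.05 log units; within the scatter) is within the scatter, so the two compounds cannot be ordered on these data.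

The next compound, compound 3 `c1ccc(-c2ncnc3c2cnn3CCN2CCCCC2)nc1`, differs from compound 2 in one place: pyridin-2-yl in place of 4-fluoro-2-methylphenyl on an aromatic carbon.

Within the data shown here, only one measured step bears on this change, a 1.1-fold higher number from compound 1 to compound 2 (0.05 log units; within the scatter), and it concerns a swap of substituents on the same six-membered carbon ring rather than the exchange of that ring for pyridin-2-yl. It shows that the aryl substituents can be changed without moving the number beyond the scatter; it says nothing about the ring itself. Among the measured compounds shown here, with no step covering the entry of a ring nitrogen, the expectation for compound 3 rests on that tolerance and on the absence of any other guide. Compound 3 is expected to give roughly 120 nM in this assay, within a range of 40 nM to 400 nM. The step that this estimate means, a 2.5-fold higher number from compound 2 to compound 3 (0.40 log units; beyond the scatter), is expected to be a modest weakening, uncertain in size.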

Compound 3, inhibition constant: 634 nM
For compound 3 the middle estimate is 5.3-fold (0.72 log units) below the measured one; measured number above the stated range.
By their numbers in this assay, from the lowest: compounds 1 and 2 (each within the scatter of the next); then compound 3.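

In this assay, the position on an aromatic carbon of the shared core is not indifferent to the aryl group: the earlier tolerance held only between two substituted carbon rings, whereas pyridin-2-yl gives a 13-fold higher number from compound 2 to compound 3 (1.12 log units; beyond the scatter) and a 15-fold higher number from compound 1 to compound 3 (1.17 log units; beyond the scatter). Both large steps point the same way, so the weakening with pyridin-2-yl holds against both 4-fluoro-2-methylphenyl and 4-chlorophenyl, two groups that themselves stay within the scatter of each other. The change is not a single one, since pyridin-2-yl brings a ring nitrogen and a hydrogen-bond acceptor and also carries none of the chlorine, fluorine or methyl substituents, and no measurement offered here accounts for the result.

The compounds shown therefore leave open whether the weakening follows the ring nitrogen or the missing substituents, a question that unsubstituted phenyl at this position would separate. They also leave open whether the ring nitrogen matters by where it stands, which pyridin-3-yl or pyridin-4-yl would test, and whether a substituted pyridin-2-yl, such as 5-chloropyridin-2-yl, would recover the number.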